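The compounds below may be only part of what the source reports. "The series", "measured", "known", "first", "only" and "open" are said of these compounds alone.

Of the compounds shown here, three of one series have been measured in a functional assay on HEK293 cells for antagonist activity at transient receptor potential M8 protein (Canis lupus familiaris), read by FLIPR and calcium flux; a lower number here means a stronger inhibitor, a higher number a weaker inhibitor. Compound 1 `C(=C/C1CCCCC1)\c1nc2cc(-c3ccccc3)ccc2[nH]1` gives 110 nM. Compound 2 `FC(F)(F)c1cccnc1-c1ccc2[nH]c(/C=C/C3CCCCC3)nc2c1` gives 38 nM. Compound 3 `FC1(F)CCC(/C=C/c2nc3cc(-c4ccccc4C(F)(F)F)ccc3[nH]2)CC1` gives 21 nM, the lowest of the three numbers; its gap to compound 2 lies within the scatter, while its gap to compound 1 lies beyond it. No two of the measured compounds differ in one place only, so no single structural step can be read off from the measured set.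

Compound 4 `FC(F)(F)c1ccccc1-c1ccc2[nH]c(/C=C/C3CCSCC3)nc2c1` has not yet been measured. It differs from compound 3 by thian-4-yl in place of 4,4-difluorocyclohexyl on a double-bonded chain carbon bound to a double-bonded chain carbon. Compound 1 and compound 2 each differ from compound 3 in more than one place, so the measured values give no isolated reading on a change at this ring, and the direction of the present step cannot be taken from the data. In this assay the step of a 1.5-fold higher number from compound 3 to compound 4 (0.18 log units; within the scatter) is expected to stay within the scatter, with a somewhat higher number slightly more likely than a lower one. The estimate for compound 4 in this assay is 32 nM, with a range from 12 nM to 85 nM.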

Compound 4, half-maximal inhibitory concentration: 31 nM
For compound 4 the middle estimate is 1.0-fold (0.01 log units) above the measured one; low and high end bracket the measured number.
By their numbers in this assay, from the lowest: compounds 3, 4 and 2 (each within the scatter of the next); then compound 1.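

In this assay, for the compounds shown here, thian-4-yl in place of 4,4-difluorocyclohexyl on a double-bonded chain carbon bound to a double-bonded chain carbon gives a 1.5-fold higher number from compound 3 to compound 4 (0.17 log units; within the scatter) and is the first step that isolates a change at this ring. The earlier compounds shown here gave no reading here, and this step shows that the ring can be exchanged without leaving the scatter, even though the entering group has 6 heavy atoms against 8, holds sulfur in the ring in place of two fluorine atoms on it, and counts 1 hydrogen-bond acceptor where the leaving group has 0. No available measurement accounts for this outcome.

Still open, going by these compounds, is whether the position accepts a charged or more strongly changed group, such as a piperidine ring with its amine nitrogen or a cyclohexane ring carrying a carboxylic acid. On these data alone, it is also open whether the same ring exchange would read alike on the other aryl groups of the series, those of compound 1 and compound 2, since this step rests on a single pair.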